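Notes on a four-compound growth-inhibition series

This account rests on a few compounds, and the source may have more. Where it says the series, first, only, none or still open, it means among the compounds named here.

Compound 1 `CN(C)c1ccc(/C=C(/Sc2ccccc2Br)C(=O)c2ccc(Br)cc2)cc1`: > 100000 nM in a functional assay on DU-145 cells (Homo sapiens) for inhibition, read by trypan blue exclusion, with a stated time of 96 h (on this read-out lower numbers stand for stronger inhibition of growth and higher numbers for weaker inhibition of growth), a limit.
Compound 2 `O=C(/C(=C\c1c(O)cc(O)cc1O)Sc1ccccc1Br)c1ccc(Br)cc1`: > 100000 nM, a limit.
Compound 3 `CN(C)c1ccc(/C=C(/SCc2ccc(Cl)cc2Cl)C(=O)c2ccc(Cl)cc2)cc1`: 50000 nM.

Compound 1 and compound 2 are both reported only as limits, so the step that the two limits leave unreadable from compound 1 to compound 2 cannot be read in size; the change between them is 2,4,6-trihydroxyphenyl in place of 4-(dimethylamino)phenyl on a double-bonded chain carbon bound to a double-bonded chain carbon. Going by the values given here, compound 3 gives the only number in this assay; how its core differs from the core of compound 1 is not broken down here. Compound 4 `O=C(/C(=C\c1c(O)cc(O)cc1O)SCc1ccc(Cl)cc1Cl)c1ccc(Cl)cc1` carries the same change on the core of compound 3, namely (2,4,6-trihydroxyphenyl in place of 4-(dimethylamino)phenyl on a double-bonded chain carbon bound to a double-bonded chain carbon). The earlier step offers no size, and the limit of > 100000 nM in this assay, at which 2 of the 3 values shown sit, shows how near the measured value of compound 3 already lies to that limit. Compound 4 is expected to stay weak, with the step of a 1.4-fold higher number from compound 3 to compound 4 (0.15 log units; within the scatter) estimated as small. For compound 4 the estimate is 70000 nM, ranging from 20000 nM to 200000 nM, with a fair chance that only a limit is reported.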

Compound 4, concentration for 50% growth inhibition: 25000 nM
For compound 4 the middle estimate is 2.8-fold (0.45 log units) above the measured one; the measured number falls inside the stated range.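

In this assay, 2,4,6-trihydroxyphenyl in place of 4-(dimethylamino)phenyl on the core of compound 3 gives a 2.0-fold lower number from compound 3 to compound 4 (0.30 log units; within the scatter). Going by these compounds, the same change on the core of compound 1 cannot be read in size, so whether it carries from one core to the other stays unknown: the limit of > 100000 nM in this assay, at which 2 of the 4 values shown sit. The pair compound 3 and compound 4 therefore shows only a step within the scatter on one core, and no transfer of the change between cores.

Open, on these data alone, is whether a phenyl carrying a carboxylic acid or a primary amine, on a double-bonded chain carbon bound to a double-bonded chain carbon, would give a step beyond the scatter. Also open, as far as these compounds go, is how the change reads on a core whose values stand clear of the limit.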